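Swapping Chloro for Bromo on the Hydroxyphenyl Ring

The source may report more compounds than this note shows. Statements on the series, on what has been measured and on what is new or still open speak of the compounds shown alone.

Measured in a functional assay on EC9706 cells (Homo sapiens) for antiproliferative activity, read by MTT assay, with a stated time of 72 h; a higher number here means a weaker inhibitor, a lower number a stronger inhibitor:
- compound 1 `O=C(N/N=C/c1ccccn1)c1cccc(S(=O)(=O)N2CCOCC2)c1`: 44300 nM
- compound 2 `COc1ccc(/C=N/NC(=O)c2cccc(S(=O)(=O)N3CCOCC3)c2)c(O)c1`: 1090 nM
- compound 3 `O=C(N/N=C/c1cc(Cl)ccc1O)c1cccc(S(=O)(=O)N2CCOCC2)c1`: 2150 nM

Compound 3 cannot be separated from compound 2, as a 2.0-fold higher number from compound 2 to compound 3 (0.30 log units; within the scatter) shows. Both stand well apart from compound 1, and the gap on the side of compound 3 is a 21-fold lower number from compound 1 to compound 3 (1.31 log units; beyond the scatter).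

The next compound is compound 4 `O=C(N/N=C/c1cc(Br)ccc1O)c1cccc(S(=O)(=O)N2CCOCC2)c1`, which carries bromo in place of chloro on an aromatic carbon, para to a hydroxy group: bromo in place of chloro on an aromatic carbon.

Within the data shown here, no measured step makes this exchange, so the evidence is indirect. The large changes, a 41-fold lower number from compound 1 to compound 2 (1.61 log units; beyond the scatter) and a 21-fold lower number from compound 1 to compound 3 (1.31 log units; beyond the scatter), both replace the pyridin-2-yl group with a substituted hydroxyphenyl group, a far bigger edit than the one at hand. The closest comparison is a 2.0-fold higher number from compound 2 to compound 3 (0.30 log units; within the scatter), in which 5-chloro-2-hydroxyphenyl replaces 2-hydroxy-4-methoxyphenyl. Even that wider change to the ring's substituents stayed within the scatter in this assay. A single halogen exchange is therefore expected to produce no step beyond the scatter, and no direction is favoured with any confidence.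

The expected change is a 1.1-fold lower number from compound 3 to compound 4 (0.03 log units; within the scatter).

Compound 4 is estimated at 2000 nM, with an expected range from 900 nM to 4500 nM.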

Compound 4, half-maximal inhibitory concentration: 29700 nM
Compound 4: middle estimate off by 15-fold (1.17 log units), on the low side; measured number outside the range, above it.
By their numbers in this assay, from the lowest: compounds 2 and 3 (each within the scatter of the next); then compounds 4 and 1 (each within the scatter of the next).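

In this assay, this place on the ring, an aromatic carbon para to a hydroxy group, turned out to be sensitive to the identity of the halogen: one heavy atom replaced another, with no change in the counted hydrogen-bond donors, acceptors or net charge, yet bromo in place of chloro gave a large step (a 14-fold higher number from compound 3 to compound 4 (1.14 log units; beyond the scatter)). The hydroxyphenyl groups therefore do not behave as one class, since the bromo compound is set well apart from the methoxy-bearing compound (a 27-fold higher number from compound 2 to compound 4 (1.44 log units; beyond the scatter)), while the step from the pyridin-2-yl compound stays within the scatter (a 1.5-fold lower number from compound 1 to compound 4 (0.17 log units; within the scatter)), so the large gains seen earlier from compound 1 do not extend to compound 4. No measurement in hand accounts for this sharp difference between two halogens.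

The compounds shown leave open whether chloro is unusually favourable here or bromo unusually unfavourable, a question that fluoro, iodo, methyl or an amine at the same place would help settle. They also leave open whether the same exchange would matter as much on a ring that also carries a methoxy group.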